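The source may hold more compounds than are shown below. What is called first, only, known or untested is meant among the compounds shown, and "the series" means these compounds.

Measured compounds:
Compound 1, `Cn1cnc2c(Nc3ccccc3)ncnc21`: 0%
Compound 2, `Cn1cnc2c(Nc3ccc(F)cc3)ncnc21`: 7%
Compound 3, `c1ccc(-[n+]2c[nH]c3ncncc32)cc1`: 0%

The read-out is an assay on isolated protein for inhibition of Rho-associated protein kinase 1 (Homo sapiens), tested at 30 uM; a lower number here means less inhibition, a higher number more inhibition at the concentration tested (going by the name of the read-out). Compound 1 gives 0% and compound 2 gives 7%; the change between these two is fluoro in place of hydrogen on an aromatic carbon, and it made a step of a number 7 percentage points higher from compound 1 to compound 2 (within the scatter). In this assay compound 3 gives 0%; the difference between its core and the core of compound 1 is not broken down here. Compound 4, `Fc1ccc(-[n+]2c[nH]c3ncncc32)cc1`, has not been measured. It differs from compound 3 by fluoro in place of hydrogen on an aromatic carbon, the same kind of change as the earlier one, though here the fluoro sits para to a group of 9 heavy atoms rather than para to a large group. For compound 4 the expected step is a number 3 percentage points higher from compound 3 to compound 4 (within the scatter), because the same kind of change gave a number 7 percentage points higher from compound 1 to compound 2 (within the scatter). Compound 4 is therefore estimated at 3%, between 0% and 12%.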

Compound 4, a percentage reported as inhibition, at one concentration (the size of the read-out at that concentration, not a potency): 2%
Compound 4: middle estimate off by 1 percentage points, on the high side; measured number inside the range.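

The new step in this assay is a number 2 percentage points higher from compound 3 to compound 4 (within the scatter). Set beside the earlier step, fluoro in place of hydrogen on an aromatic carbon reads alike on the two cores: the same change on two cores in this assay, a number 7 percentage points higher (within the scatter) from compound 1 to compound 2 and a number 2 percentage points higher (within the scatter) from compound 3 to compound 4, 5 percentage points apart, within the scatter of two such steps. This shows that the change carried from one core to the other without a difference that can be told from the scatter, but it does not show that fluoro alters inhibition on either core, and two cores make no rule for others.

From the compounds shown here alone, it remains open whether an amine, a carboxylic acid or a longer chain in place of that hydrogen would give a step beyond the scatter. Also open, going by these compounds, is how fluoro would behave elsewhere on the six-membered aromatic ring.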